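Butyl Chain Extension on the Core: Cytotoxicity Outlook

A few compounds are considered here, and "the series" means these few. Any claim that something is new, unique, unknown or untested is made for them only; others in the source may bear on it.

Compound 1 `CC(=O)C1=C(O)/C(=C/c2ccc(C(F)(F)F)cc2)N(C(C)=O)C1=O` and compound 2 `CCCC(=O)C1=C(O)/C(=C/c2ccccc2)N(C(C)=O)C1=O` share one core. In an ADME assay on HEK293 cells (Homo sapiens) for cytotoxicity (on this read-out lower numbers stand for higher toxicity in this test and higher numbers for lower toxicity in this test), compound 1 gives only a limit, > 32 ug/mL. In this assay compound 2 likewise gives only a limit, > 32 ug/mL. Compound 2 thus sits at the assay limit, as the limit of > 32 ug/mL in this assay, at which 2 of the 2 values shown sit, shows. Compound 3 `CCCCCCCC(=O)C1=C(O)/C(=C/c2ccccc2)N(C(C)=O)C1=O` differs from compound 2 by butyl in place of hydrogen on a saturated chain carbon, three bonds along the chain from a carbonyl carbon. Among the compounds with values here, no measured step guides this change, so a modest step of about an at least 1.1-fold lower number from compound 2 to compound 3 (0.05 log units; that floor lies within the scatter) toward greater toxicity is expected, possibly within the scatter. Compound 3 is estimated at 28 ug/mL, from 10 ug/mL to 64 ug/mL.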

Compound 3, half-maximal cytotoxic concentration: > 32 ug/mL
Compound 3 gave a limit, no number; the forecaster's own chance of this, stated with the estimate: 45%; middle value at least 1.1-fold (0.05 log units) away from the limit.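

No step can be read from compound 2 to compound 3, since both give only a limit in this assay: the limit of > 32 ug/mL in this assay, at which 3 of the 3 values shown sit. From the compounds shown here alone, whether butyl in place of hydrogen changes the read-out in this assay at all remains open.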